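Heteroaryl exchange on the amide nitrogen: compound 2 to compound 3

The source may hold more compounds than are shown below. What is called first, only, known or untested is meant among the compounds shown, and "the series" means these compounds.

Compound 1 `CC(C)[C@H](C(=O)NCc1ccccc1)c1ccc(Cl)cc1` in a functional assay on CHO cells for agonist activity at Free fatty acid receptor 2 (Homo sapiens), read by cAMP accumulation (on this read-out lower numbers stand for stronger inhibition and higher numbers for weaker inhibition), returns only a limit, > 100000 nM. For the measured compounds named here, compound 2 `CC(C)[C@H](C(=O)Nc1ncc[nH]1)c1ccc(Cl)cc1` in this assay gives 20000 nM, the single numerical value in the set, so compound 2 stands alone as the reference point. The step of an at least 5.0-fold lower number from compound 1 to compound 2 (0.69 log units; beyond the scatter) shows that a five-membered aromatic ring with 2 hetero atoms on the amide nitrogen beats benzyl by at least a modest margin, though the full size of that step is hidden by the limit (the limit of > 100000 nM in this assay, at which 1 of the 2 values shown sits). Compound 3 `Cc1csc(NC(=O)[C@H](c2ccc(Cl)cc2)C(C)C)n1` carries 4-methyl-1,3-thiazol-2-yl in place of 1H-imidazol-2-yl on an amide-type nitrogen. Going by the values given here, no measured step compares two such heteroaryl amides, so the only precedent is the exchange from compound 1 to compound 2, which moved toward lower numbers. A change of similar character is expected to keep or somewhat lower the number, with direction uncertain. Compound 3 is therefore expected at 5000 nM in this assay, within 800 nM to 30000 nM, an expected step of a 4.0-fold lower number from compound 2 to compound 3 (0.60 log units; beyond the scatter).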

Compound 3, half-maximal inhibitory concentration: 1400 nM
Compound 3: middle estimate off by 3.6-fold (0.55 log units), on the high side; low and high end bracket the measured number.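

On the amide nitrogen, the identity of the five-membered aromatic ring with 2 hetero atoms matters and not only its presence: 4-methyl-1,3-thiazol-2-yl in place of 1H-imidazol-2-yl gives a 14-fold lower number from compound 2 to compound 3 (1.15 log units; beyond the scatter) in this assay. This single exchange changes the ring atoms, adds the methyl group and removes the ring's hydrogen-bond donor, so the step cannot be assigned to any one of these. Against benzyl the result is an at least 71-fold lower number from compound 1 to compound 3 (1.85 log units; beyond the scatter), a bound only, as the value of compound 1 is a limit: the limit of > 100000 nM in this assay, at which 1 of the 3 values shown sits.

Going by these compounds, whether the methyl group contributes to the step remains open, and a comparison of 1,3-thiazol-2-yl without the methyl group against compound 3 would address this. On these data alone, how a 4-ethyl or 4-carboxylic acid group on the same ring would read is also open.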